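Methoxy addition on the aryl ring: working notes on the series

The compounds below may be only part of what the source reports. "The series", "measured", "known", "first", "only" and "open" are said of these compounds alone.

Compound 1 `CC1=CC[C@H](C(C)(C)NC(=S)N/N=C/c2ccc(O)cc2)CC1` and compound 3 `CC1=CC[C@H](C(C)(C)NC(=S)N/N=C(\C)c2ccccc2)CC1` are the two measured parents; the difference between the two cores is not broken down here. In an ADME assay on Vero cells (Chlorocebus sabaeus) for inhibition, read by sulforhodamine B assay, with a stated time of 48 h (on this read-out lower numbers stand for stronger inhibition of growth and higher numbers for weaker inhibition of growth), compound 1 gives > 100000 nM, which is a limit of the assay and not a number. Compound 2 `COc1cc(/C=N/NC(=S)NC(C)(C)[C@H]2CC=C(C)CC2)ccc1O` carries methoxy in place of hydrogen on an aromatic carbon. In this assay compound 2 gives 91800 nM. The resulting step is an at least 1.0-fold lower number from compound 1 to compound 2 (0.03 log units; that floor lies within the scatter). In this assay compound 3 gives > 100000 nM, again a limit of the assay rather than a number. Two of the three values shown sit at the limit of > 100000 nM in this assay, at which 2 of the 3 values shown sit.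

Compound 4 `COc1ccc(/C(C)=N/NC(=S)NC(C)(C)[C@H]2CC=C(C)CC2)cc1` is not yet measured and carries methoxy in place of hydrogen on an aromatic carbon. The place is not the same as in compound 2, where the methoxy sits ortho to a hydroxy group and meta to a large group, while in compound 4 it sits para to a large group; it is the same kind of change, not the same one. From compound 3 to compound 4 a step of a number no higher from compound 3 to compound 4 (the limit leaves the size open) is expected, because the same kind of change gave an at least 1.0-fold lower number from compound 1 to compound 2 (0.03 log units; that floor lies within the scatter). Compound 4 is therefore estimated at 100000 nM, between 40000 nM and 250000 nM.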

Compound 4, concentration for total growth inhibition: > 100000 nM
Compound 4: no number, only a limit (the forecaster's own chance of this, stated with the estimate: 60%); the middle value lies on the limit itself.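

In this assay compound 4 gives > 100000 nM, a limit of the assay and not a number. Compound 3 also stands at a limit, so no step can be read between compound 3 and compound 4: the limit of > 100000 nM in this assay, at which 3 of the 4 values shown sit.

The compounds shown leave open whether phenyl to 4-methoxyphenyl changes the read-out on the core of compound 3 at all.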